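The source may report more compounds than this note shows. Statements on the series, on what has been measured and on what is new or still open speak of the compounds shown alone.

In a functional assay on Jurkat cells (Homo sapiens) (on this read-out lower numbers stand for stronger inhibition and higher numbers for weaker inhibition), compound 1 `CC(C)[C@H](NC(=O)COc1cccc2ccccc12)C(=O)N[C@@H](CC(=O)O)C(=O)COc1ccc([N+](=O)[O-])cc1` gives only a limit, > 100000 nM. For the measured compounds named here, compound 2 `CC(C)[C@H](NC(=O)COc1cccc2ccccc12)C(=O)N[C@@H](CC(=O)O)C(=O)COc1c(F)cc(F)cc1F` gives 6840 nM, the only actual number so far. Between them lies an at least 14-fold lower number from compound 1 to compound 2 (1.16 log units; beyond the scatter), a large step made by 2,4,6-trifluorophenyl replacing 4-nitrophenyl. Compound 3 `CC(C)[C@H](NC(=O)COc1cccc2ccccc12)C(=O)N[C@@H](CC(=O)O)C(=O)COc1c(Cl)cccc1Cl` changes the same place: 2,6-dichlorophenyl in place of 2,4,6-trifluorophenyl on an oxygen on a saturated carbon. That single earlier step involved a different pair of groups, so it shows that this place can matter but does not set a size here. No clear shift is therefore expected, and the estimated change is a 1.4-fold lower number from compound 2 to compound 3 (0.14 log units; within the scatter). For compound 3, the expected value is 5000 nM, with an estimated range from 1200 nM to 20000 nM.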

Compound 3, half-maximal inhibitory concentration: 3000 nM
The estimate for compound 3 lay 1.7-fold (0.22 log units) above the measured number; measured number inside the range.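

Within this assay, replacing 2,4,6-trifluorophenyl with 2,6-dichlorophenyl gives a 2.3-fold lower number from compound 2 to compound 3 (0.36 log units; beyond the scatter) and so shows that even two halogen-bearing phenyl groups can be told apart at this place. The change from 4-nitrophenyl is much larger, with an at least 33-fold lower number from compound 1 to compound 3 (1.52 log units; beyond the scatter) as its reading. Compound 1 gives a limit and not a number: the limit of > 100000 nM in this assay, at which 1 of the 3 values shown sits.

The two halogen-bearing groups differ in the halogen, its count and its placing all at once, so these compounds cannot separate those three changes. Going by these compounds, how a plain phenyl or a methoxyphenyl would read at this place also stays open.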